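Swapping the thiophene for a pentyl chain

The source may report more compounds than this note shows. Statements on the series, on what has been measured and on what is new or still open speak of the compounds shown alone.

Measured so far in a functional assay on K562 cells (Homo sapiens) for inhibition, read by fluorescence, with a stated time of 72 h; a higher number here means a weaker inhibitor of growth, a lower number a stronger inhibitor of growth:
- compound 1, `Cc1nc(CCO)cc2nn(-c3ccccc3)cc12`: > 100000 nM
- compound 2, `Cc1nc(-c2ccccc2)cc2nn(-c3ccccc3)cc12`: 6300 nM
- compound 3, `Cc1nc(-c2ccsc2)cc2nn(-c3ccccc3)cc12`: 10000 nM

Compound 1 gives only a limit in this assay, (the limit of > 100000 nM in this assay, at which 1 of the 3 values shown sits), not a number. Compound 3 has the highest of the two numbers in this assay, and compound 2 sits nearest to it; the step of a 1.6-fold higher number from compound 2 to compound 3 (0.20 log units; within the scatter) lies within the scatter, so the two cannot be ranked against each other. The two steps from the limit are both large: an at least 15-fold lower number from compound 1 to compound 2 (1.20 log units; beyond the scatter) and an at least 10-fold lower number from compound 1 to compound 3 (1.00 log units; beyond the scatter), each exchanging the 2-hydroxyethyl group for an aromatic ring.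

Compound 4, `CCCCCc1cc2nn(-c3ccccc3)cc2c(C)n1`, is not yet measured. It differs from compound 3 in one place: pentyl in place of thiophen-3-yl on an aromatic carbon. Among the measured compounds shown here, no measured step covers this kind of change. The steps from compound 1 show that an aromatic ring in this position gives a far lower number than a short chain carrying a hydroxyl, while the step between compound 2 and compound 3 shows the two rings to be interchangeable. A pentyl chain is neither a ring nor the hydroxyl-bearing chain of compound 1, so the step is expected to be uncertain, with a modest rise in number for compound 4 the more likely outcome, a 2.5-fold higher number from compound 3 to compound 4 (0.40 log units; beyond the scatter). The estimate for compound 4 in this assay is therefore 25000 nM, expected between 6000 nM and 100000 nM.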

Compound 4, concentration for 50% growth inhibition: 6900 nM
Beside the measured number, compound 4's estimate is 3.6-fold (0.56 log units) above it, within the range that was stated.
By their numbers in this assay, from the lowest: compounds 2, 4 and 3 (each within the scatter of the next). At a limit, above all of these: compound 1.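

In this assay, an aromatic ring turns out not to be required at this position: pentyl has no ring, yet it cannot be told apart from either ring, with a 1.4-fold lower number from compound 3 to compound 4 (0.16 log units; within the scatter) and a 1.1-fold higher number from compound 2 to compound 4 (0.04 log units; within the scatter). The earlier compounds shown here compared only rings with the hydroxyl-bearing chain of compound 1, so they could not separate the presence of a ring from the loss of that chain, and this result shows that a chain can serve here as well as a ring does. The contrast therefore moves to the chains themselves, with propyl in place of hydroxy giving an at least 14-fold lower number from compound 1 to compound 4 (1.16 log units; beyond the scatter), and that step is measured from a value that is only a limit, not a number: the limit of > 100000 nM in this assay, at which 1 of the 4 values shown sits.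

The 2-hydroxyethyl and pentyl chains differ both in length and in the hydroxy group, so the compounds shown cannot say which of the two matters, and an ethyl chain or a pentyl chain ending in hydroxy would separate them. Going by these compounds, it also remains open whether a longer chain such as octyl, or an amine at the end of the chain, would move the number beyond the scatter.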